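The source may hold more compounds than are shown below. What is called first, only, known or untested is meant among the compounds shown, and "the series" means these compounds.

The three compounds measured so far in a physicochemical assay for solubility, at pH 7.4 (on this read-out higher numbers stand for higher solubility and lower numbers for lower solubility), are:

Compound 1, `Cc1cc(NC(=O)Nc2ncccc2C)c2ccccc2n1`: 1300 nM
Compound 2, `Cc1cc(NC(=O)Nc2ccccc2[N+](=O)[O-])c2ccccc2n1`: 200 nM
Compound 3, `Cc1cc(NC(=O)Nc2ccc(Cl)c(Cl)c2)c2ccccc2n1`: 300 nM

Compound 1 stands highest of these three numbers in this assay. Its nearest neighbour is compound 3, whose value lies a good way lower, beyond the usual scatter of such measurements; compound 2 lies furthest from it, also beyond the scatter. None of the three pairs differs in only one place, so no single-change step can be read from them.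

The next compound is compound 4, `Cc1cc(NC(=O)Nc2cccc(F)c2)c2ccccc2n1`, not yet measured in this assay. Compared with compound 1 it carries one change: 3-fluorophenyl in place of 3-methylpyridin-2-yl on an amide-type nitrogen.

Because compound 2 gives 200 nM and compound 3 gives 300 nM, both with a carbon-only six-membered aromatic ring on the amide-type nitrogen, the expectation is that compound 4 will also fall below compound 1 in this assay, by a step beyond the scatter. The step from compound 1 to compound 4 is estimated as a 3.3-fold lower number from compound 1 to compound 4 (0.51 log units; beyond the scatter), in the downward direction. Compound 4 is therefore expected to come in at about 400 nM, with a likely range from 150 nM to 1200 nM.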

Compound 4, solubility: 100 nM
The estimate for compound 4 lay 4.0-fold (0.60 log units) above the measured number, and the stated range ends above it.
By their numbers in this assay, from the lowest: compounds 4, 2 and 3 (each within the scatter of the next, the first and the last beyond it); then compound 1.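

Within the data shown here, this is the first single-change step the series offers. In this assay the exchange of 3-methylpyridin-2-yl for 3-fluorophenyl on an amide-type nitrogen, whose other neighbour is the carbonyl carbon, gives a 13-fold lower number from compound 1 to compound 4 (1.11 log units; beyond the scatter), a large move well beyond the scatter, so this position is clearly not indifferent to the group it carries. The size of the step comes with no change in the heavy-atom count, since both groups have 7 heavy atoms and both are six-membered aromatic rings, while the counted differences are the ring nitrogen and the 1 hydrogen-bond acceptor of the leaving group, against none in the entering group, together with fluorine in place of methyl. Nothing measured here bears on why the number moves at this position.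

Which part of the exchange carries the step stays open, as no pair shown keeps the ring nitrogen fixed while the methyl and fluorine differ, or the reverse. On these data alone, how a 3-methylphenyl group, a 3-fluoropyridin-2-yl group, or a pyridin-2-yl ring bearing an amine or a carboxylic acid would stand in this assay also remains open.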